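The compounds below may be only part of what the source reports. "The series", "measured", "known", "first", "only" and "open" are said of these compounds alone.

Measured compounds:
compound 1, `CCc1ccccc1C(=O)Nc1ccc2nc(N3CCN(CC)CC3)cc(C)c2c1` — 23900 nM
compound 2, `CCN1CCN(c2cc(C)c3cc(NC(=O)c4cccc(F)c4)ccc3n2)CC1` — 24900 nM
compound 3, `CCN1CCN(c2cc(C)c3cc(NC(=O)c4ccc[nH]4)ccc3n2)CC1` — 13200 nM

All three share one core and differ only in the group attached to the carbonyl carbon of the amide. In a functional assay on SK-BR-3 cells (Homo sapiens) for antiproliferative activity, read by MTT assay, with a stated time of 72 h (a higher number here means a weaker inhibitor, a lower number a stronger inhibitor), compound 1 gives 23900 nM, compound 2 gives 24900 nM and compound 3 gives 13200 nM. Compound 1 sits almost on top of compound 2, with a 1.0-fold higher number from compound 1 to compound 2 (0.02 log units; within the scatter); its gap to compound 3 is a 1.8-fold lower number from compound 1 to compound 3 (0.26 log units; within the scatter), and the gap between the other two is a 1.9-fold lower number from compound 2 to compound 3 (0.28 log units; within the scatter). Among the measured compounds shown here, every measured step therefore stays within the scatter, so the numbers so far give no sign that swapping one of these carbonyl-bound groups for another moves the read-out.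

Compound 4, `CCN1CCN(c2cc(C)c3cc(NC(=O)c4cccc(C)c4)ccc3n2)CC1`, is the next member of this set. Against compound 1 the change is 3-methylphenyl in place of 2-ethylphenyl on a carbonyl carbon. The closest guide is compound 2, which also carries a group substituted on the phenyl ring at the same place, and the step to it, a 1.0-fold higher number from compound 1 to compound 2 (0.02 log units; within the scatter), is flat. The change from compound 1 to compound 4 is therefore expected to be a 1.1-fold lower number from compound 1 to compound 4 (0.04 log units; within the scatter), not beyond the scatter. Compound 4 is expected to give about 22000 nM in this assay, within a range from 9000 nM to 55000 nM.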

Compound 4, half-maximal inhibitory concentration: 13700 nM
Beside the measured number, compound 4's estimate is 1.6-fold (0.21 log units) above it; the range from low to high includes it.
By their numbers in this assay, from the lowest: compounds 3, 4, 1 and 2 (each within the scatter of the next).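

Compound 4 adds a fourth group on the carbonyl carbon, and the read-out in this assay still does not separate it from the others: replacing 2-ethylphenyl gives a 1.7-fold lower number from compound 1 to compound 4 (0.24 log units; within the scatter) and so stays inside the usual spread of repeat measurements. The two closest comparisons agree, since methyl in place of fluoro on an aromatic carbon gives a 1.8-fold lower number from compound 2 to compound 4 (0.26 log units; within the scatter) and 3-methylphenyl in place of 1H-pyrrol-2-yl gives a 1.0-fold higher number from compound 3 to compound 4 (0.02 log units; within the scatter), which means that neither the substituent on the phenyl ring nor the kind of aromatic ring has yet produced a step that can be told from noise. No supporting measurement is available to explain these results.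

Every group shown on this carbonyl carbon is an aromatic ring, so it remains open whether an amine, a carboxylic acid or a longer alkyl chain at this place would give a step beyond the scatter. The ethylpiperazine-bearing shared core is also constant in all four compounds, leaving open whether a change elsewhere in the molecule would move the read-out more than these swaps have.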